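The compounds below may be only part of what the source reports. "The series", "measured", "known", "first", "only" and "open" are said of these compounds alone.

Compound 1 `O=C(COCc1ccccc1)N1CCN(c2ccc(Cl)cc2)CC1`: in a functional assay on HEK293 cells for positive allosteric modulation of metabotropic glutamate receptor 5 (Homo sapiens), read by FLIPR and calcium flux (on this read-out lower numbers stand for an effect already at smaller amounts and higher numbers for an effect only at larger amounts of compound), compound 1 gives 350 nM.
Compound 2 `O=C(COCc1ccccc1)N1CCN(c2ccncc2)CC1`: compound 2 gives > 25000 nM, which is a limit of the assay and not a number.
Compound 3 `O=C(COCc1ccncc1)N1CCN(c2ccc(Cl)cc2)CC1`: compound 3 gives 1300 nM.

Of the two numbers that are numbers, compound 3 holds the higher one; its nearest neighbour is compound 1, and the gap between them is a 3.7-fold higher number from compound 1 to compound 3 (0.57 log units; beyond the scatter), a swap of phenyl for pyridin-4-yl on the chain carbon next to the ether oxygen. The other measured step, an at least 71-fold higher number from compound 1 to compound 2 (1.85 log units; beyond the scatter), swaps the aryl group on the piperazine nitrogen for pyridin-4-yl and runs into (the limit of > 25000 nM in this assay, at which 1 of the 3 values shown sits).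

Compound 4 `O=C(COCc1ccncc1)N1CCN(c2ccc(Cl)cc2F)CC1` differs from compound 3 only by fluoro in place of hydrogen on an aromatic carbon. Neither measured step adds a single atom to the aryl ring on the nitrogen; both replace a whole ring, and the larger of them shows that this side of the molecule is sensitive to change. A single fluoro is a far smaller alteration than either, so the expected step of a 1.3-fold lower number from compound 3 to compound 4 (0.11 log units; within the scatter) in this assay is small, with no firm direction. Compound 4 is therefore estimated at 1000 nM, within a range of 350 nM to 3500 nM.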

Compound 4, half-maximal effective concentration: 600 nM
Beside the measured number, compound 4's estimate is 1.7-fold (0.22 log units) above it; measured number inside the range.
By their numbers in this assay, from the lowest: compounds 1 and 4 (each within the scatter of the next); then compound 3. At a limit, above all of these: compound 2.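

The earlier steps shown here each replaced a whole ring and each gave a higher number, whereas fluoro in place of hydrogen on the 4-chlorophenyl ring moves the number the other way in this assay, with a 2.2-fold lower number from compound 3 to compound 4 (0.34 log units; beyond the scatter). This shows that the ring on the piperazine nitrogen accepts a small addition without any loss, and that a single extra atom, ortho to a large group and meta to the chloro group, is enough to shift the number beyond the scatter. Nothing measured here says why this one atom has that effect.

From the compounds shown here alone, it stays open whether the step belongs to fluoro itself, since a chloro, a methyl or a methoxy group on the same aromatic carbon would show if other small groups act alike, and whether fluoro on other carbons of this ring would do the same. Going by these compounds, it also stays open whether the same change would give a similar step on compound 1, which carries phenyl in place of pyridin-4-yl at the other end of the molecule.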